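Replacing a 3,4-Dimethoxyphenyl Group in a Cell Inhibition Series

The compounds below may be only part of what the source reports. "The series", "measured", "known", "first", "only" and "open" are said of these compounds alone.

Measured compounds:
compound 1 `Cc1n[nH]c2ccc(-c3nc4cnc(N5CCN(C)CC5)cn4c3Nc3cccc(Cl)c3)cc12`: "not determined" (no result reported)
compound 2 `Cc1n[nH]c2ccc(-c3nc4cnc(N5CCN(C)CC5)cn4c3Nc3ccccc3)cc12`: "not determined" (no result reported)
compound 3 `COc1ccc(Nc2c(-c3ccc4[nH]nc(C)c4c3)nc3cnc(N4CCN(C)CC4)cn23)cc1OC`: 0%

Three compounds share a core and differ only in the aryl group carried on a nitrogen on an aromatic ring. In a functional assay on CWR22R cells (Homo sapiens) for inhibition, with a stated time of 120 h, tested at 10 uM (on this read-out lower numbers stand for less inhibition and higher numbers for more inhibition at the one concentration tested (going by the name of the read-out)), compound 3 gives 0%, which means no measurable inhibition at the single concentration tested. For the measured compounds named here, compound 1 and compound 2 carry no result in this assay, so compound 3 stands alone as the only compound with a number, and it sits at the bottom of the scale.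

Compound 4 `Cc1n[nH]c2ccc(-c3nc4cnc(N5CCN(C)CC5)cn4c3Nc3ccc(F)c(Cl)c3)cc12` is the next compound to be tested. It differs from compound 3 in one place: 3-chloro-4-fluorophenyl in place of 3,4-dimethoxyphenyl on a nitrogen on an aromatic ring

Going by the values given here, no pair of measured compounds differs in a single place, so the data hold no step whose size could guide this change. Among the compounds with values here, the only anchor is compound 3 with its 0%. On that basis, the step from compound 3 to compound 4 in this assay is expected to be a number 5 percentage points higher from compound 3 to compound 4 (within the scatter), that is, no movement beyond the usual scatter. Compound 4 is therefore expected to give about 5% in this assay, with a plausible range from -5% to 25%.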

Compound 4, a percentage reported as inhibition, at one concentration (the size of the read-out at that concentration, not a potency): 0.82%
The estimate for compound 4 lay 4.2 percentage points above the measured number, within the range that was stated.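

In this assay, putting 3-chloro-4-fluorophenyl in place of 3,4-dimethoxyphenyl on a nitrogen on an aromatic ring gives a number 0.8 percentage points higher from compound 3 to compound 4 (within the scatter), so this one change does not separate the two compounds on this read-out. The swap is not a small one on paper: the leaving group counts 2 hydrogen-bond acceptors and the entering group 0, yet the read-out stays within its usual scatter, and both compounds remain at the low end of the scale at the single concentration tested. No measurement shown here offers an explanation for this result.

The steps involving compound 1 and compound 2 cannot be read, so the plain phenyl and 3-chlorophenyl versions add nothing to the picture at this position. Also open, going by these compounds, is whether any group on this nitrogen can raise the inhibition beyond the scatter, for example a phenyl ring carrying a carboxylic acid or an amine, or a non-aromatic group such as cyclohexyl.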